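The compounds below may be only part of what the source reports. "The series", "measured", "known", "first", "only" and "open" are said of these compounds alone.

Among the compounds with values here, in an ADME assay on HUVEC cells (Homo sapiens) for cytotoxicity, read by MTT assay, with a stated time of 16 h (on this read-out lower numbers stand for stronger inhibition and higher numbers for weaker inhibition), three related compounds have numbers so far. Compound 1 (`COc1cc(C2Oc3cc([C@H]4Oc5cc(O)cc(O)c5C(=O)[C@@H]4O)ccc3OC2CO)ccc1OC(=O)c1cc(O)c(O)c(O)c1`) reads 35400 nM and compound 3 (`COc1cc(C2Oc3cc([C@H]4Oc5cc(O)cc(O)c5C(=O)[C@@H]4O)ccc3OC2COC(=O)c2cc(O)c(O)c(O)c2)ccc1O`) reads 55000 nM on this scale. Compound 2 (`COc1cc(C2Oc3cc([C@H]4Oc5cc(OC(=O)c6cc(O)c(O)c(O)c6)cc(O)c5C(=O)[C@@H]4O)ccc3OC2CO)ccc1O`) gives 9210 nM and so stands lowest of the three, with its distance to each of the other two beyond the usual scatter.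

Compound 4 (`COc1cc([C@@H]2Oc3cc([C@H]4Oc5cc(OC(=O)c6cc(O)c(O)c(O)c6)cc(O)c5C(=O)[C@@H]4O)ccc3O[C@H]2CO)ccc1O`) has the same atoms and bonds as compound 2, and only the drawn three-dimensional arrangement differs (the two compounds have the same atoms and bonds; at least one stereo element is drawn with a configuration in one of them and without one in the other: 2 of 4 stereo elements differ; a stereocentre at a saturated ring carbon is drawn without a configuration in compound 2 and S in compound 4; a stereocentre at a saturated ring carbon is drawn without a configuration in compound 2 and S in compound 4). A stereocentre is a carbon whose attached groups can be arranged in two mirror-image ways, so compound 4 fixes an arrangement that the drawing of compound 2 leaves open.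

Within the data shown here, no pair of measured compounds differs in one place only, so the data give no direct measure of such a change. The expectation in this assay is therefore no step beyond the scatter in either direction, with compound 2 at 9210 nM as the starting point. Among the measured compounds shown here, the estimated step (a 1.0-fold higher number from compound 2 to compound 4 (0.01 log units; within the scatter)) is small, though with no measured example the range stays wide. For compound 4 the estimated value is 9500 nM with an expected range from 4000 nM to 22000 nM in repeat measurements.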

Compound 4, half-maximal inhibitory concentration: 7850 nM
Compound 4: middle estimate off by 1.2-fold (0.08 log units), on the high side; low and high end bracket the measured number.
By their numbers in this assay, from the lowest: compounds 4 and 2 (each within the scatter of the next); then compounds 1 and 3 (each within the scatter of the next).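

In this assay the step is a 1.2-fold lower number from compound 2 to compound 4 (0.07 log units; within the scatter), so compound 4, with both saturated ring carbons drawn as S, reads the same as compound 2 within the usual scatter. Within the data shown here, this is the first measured pair that differs in one respect only, and it gives a direct look at stereochemistry, since the atoms and bonds stay the same and only the drawn arrangement at these two ring carbons changes. The step cannot be taken as a comparison of one fixed arrangement with another because of what separates this pair: the fact that one of compounds 2 and 4 is drawn with a defined configuration and the other without, at the place where they differ

The compounds shown leave open how a version with these two ring carbons drawn as R would read, and whether fixing the S arrangement would leave the number just as unmoved in compound 1 or compound 3, where the ester group sits elsewhere on the shared core. They also leave open what a carboxylic acid or an amine in place of the hydroxymethyl group would do to the number in this assay.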